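This account rests on a few compounds, and the source may have more. Where it says the series, first, only, none or still open, it means among the compounds named here.

Measured so far in a functional assay on IMR-32 cells (Homo sapiens) for cytotoxicity, read by sulforhodamine B assay, with a stated time of 48 h; on this read-out lower numbers stand for stronger inhibition and higher numbers for weaker inhibition:
compound 1 `C=CCOc1cc(Br)ccc1C(=O)c1cccnc1` gives 98000 nM
compound 2 `C=CCOc1ccc(Br)cc1C(=O)c1cccnc1` gives 88000 nM
compound 3 `C=CCOc1c(Cl)cc(Cl)cc1C(=O)c1cccnc1` gives 52000 nM

All three numbers sit close together at the weak end of the read-out. Compound 3 has the lowest of the three numbers, but its gap to compound 2 and its gap to compound 1 both fall within the usual scatter, so no order among the three is established. Among the compounds with values here, no pair of measured compounds differs in a single place, so there is no measured step to lean on.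

Compound 4 `C=CCOc1c(Cl)cccc1C(=O)c1cccnc1` is the next compound for this assay. Relative to compound 3 the change is hydrogen in place of chloro on an aromatic carbon. One of the two chloro groups of compound 3 is thus removed, the allyloxy group and the rest of the core being kept.

Within the data shown here, with no measured single-point step in this set, the expectation rests on the spread of the three values, which is narrow. In this assay the expected step is small and toward a somewhat higher number, a 1.4-fold higher number from compound 3 to compound 4 (0.16 log units; within the scatter), and it may well stay within the scatter. Compound 4 is expected to give 75000 nM in this assay, with a range from 35000 nM to 160000 nM.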

Compound 4, half-maximal inhibitory concentration: 94000 nM
Compound 4: the middle estimate sits 1.3-fold (0.10 log units) below what was measured; the range from low to high includes it.
By their numbers in this assay, from the lowest: compounds 3, 2, 4 and 1 (each within the scatter of the next).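

In this assay, within the data shown here, the replacement of chloro by hydrogen gives a 1.8-fold higher number from compound 3 to compound 4 (0.26 log units; within the scatter) and this is the first step between two compounds that differ in one place. At the aromatic carbon para to an allyloxy group and meta to a chloro group, chloro and hydrogen are therefore not told apart by this read-out, and the second chloro group of compound 3 has no established effect on the number. No measurement is at hand that would bear on the size of this step.

Still open, going by these compounds, is whether any other group on this same carbon, such as a methoxy group, an amine or a carboxylic acid, would carry the number beyond the scatter, since chloro and hydrogen are the only two substituents compared here. Equally open, on these data alone, is whether the series can move at all through changes elsewhere, for example a longer chain in place of the allyloxy group or removal of the remaining chloro group, as every value so far lies close together at the weak end of the read-out.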